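Fluoro to Chloro on the Phenyl: What Compound 4 Should Show

The compounds below may be only part of what the source reports. "The series", "measured", "known", "first", "only" and "open" are said of these compounds alone.

Compound 1 `O=C(/C=C\c1ccccc1)N1N=C(c2ccncc2)OC1c1c[nH]c2ccccc12` gives > 30 ug/mL in an ADME assay on PANC-1 cells (Homo sapiens) for cytotoxicity, read by MTT assay, with a stated time of 48 h (on this read-out lower numbers stand for stronger inhibition of growth and higher numbers for weaker inhibition of growth), and this value is a limit of the assay.
Compound 2 `O=C(/C=C\c1cccc([N+](=O)[O-])c1)N1N=C(c2ccncc2)OC1c1c[nH]c2ccccc12` gives > 30 ug/mL in this assay, again a limit.
Compound 3 `O=C(/C=C\c1cccc(F)c1)N1N=C(c2ccncc2)OC1c1c[nH]c2ccccc12` gives > 30 ug/mL in this assay, also a limit.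

Compound 3 therefore stands only at a limit, and the two other values shown are limits as well; all three sit at the limit of > 30 ug/mL in this assay, at which 3 of the 3 values shown sit. The steps a step that the two limits leave unreadable from compound 1 to compound 2, a step that the two limits leave unreadable from compound 1 to compound 3 and a step that the two limits leave unreadable from compound 2 to compound 3 can thus not be sized.

Compound 4 `O=C(/C=C\c1ccc(Cl)cc1)N1N=C(c2ccncc2)OC1c1c[nH]c2ccccc12` differs from compound 3 by 4-chlorophenyl in place of 3-fluorophenyl on a double-bonded chain carbon bound to a double-bonded chain carbon. No measured step can be read for this change; the three limits only show that hydrogen, nitro and fluoro on the phenyl all left growth inhibition weak. Compound 4 is expected to stay at the limit, estimated at 40 ug/mL (range 15 ug/mL to 150 ug/mL), an expected step that the limit leaves unreadable from compound 3 to compound 4.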

Compound 4, concentration for 50% growth inhibition: > 30 ug/mL
Compound 4 gave a limit, no number; the forecaster's own chance of this, stated with the estimate: 80%; the middle value is on the limit's open side.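

No new step can be read between compound 4 and compound 1, compound 2 or compound 3, because all four stand at a limit: the limit of > 30 ug/mL in this assay, at which 4 of the 4 values shown sit.

The compounds shown leave open how strongly any of them inhibits growth in this assay, and whether any change on the phenyl alters it.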